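Adding a Methoxy Group to a Low-Toxicity Ether

The source may hold more compounds than are shown below. What is called first, only, known or untested is meant among the compounds shown, and "the series" means these compounds.

Of the compounds shown here, two have so far been tested in an ADME assay on MT4 cells (Homo sapiens) for cytotoxicity, read by MTT assay, with a stated time of 4 days; on this read-out higher numbers stand for lower toxicity in this test and lower numbers for higher toxicity in this test. Compound 1 `COc1cc2cc(C#N)ccc2cc1Oc1ccnc(Nc2ccc(C#N)cc2)n1` reached only the limit of the test, giving > 318000 nM. Among the compounds with values here, compound 2 `N#Cc1ccc(Nc2nccc(Oc3ccc4cc(C#N)ccc4c3Cl)n2)cc1` gives 269000 nM in this assay, the only plain number among the two values. Compound 3 `COc1cc2cc(C#N)ccc2c(Cl)c1Oc1ccnc(Nc2ccc(C#N)cc2)n1` differs from compound 2 by methoxy in place of hydrogen on an aromatic carbon. Within the data shown here, no measured pair shows the effect of this particular change, so no step beyond the usual scatter is expected in either direction in this assay. Compound 3 is therefore estimated at 300000 nM, within 150000 nM to 600000 nM, which is expected to mean a step of a 1.1-fold higher number from compound 2 to compound 3 (0.05 log units; within the scatter).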

Compound 3, half-maximal cytotoxic concentration: > 190000 nM
Compound 3: only a limit was reported; the forecaster's own chance of this, stated with the estimate: 50%; the middle value is on the limit's open side.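

Within the data shown here, compound 3 gives only a limit in this assay, and no step to it can be read from compound 2 or compound 1. From the compounds shown here alone, how far methoxy or chloro in place of hydrogen shifts the cytotoxic concentration stays open.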